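The source may hold more compounds than are shown below. What is called first, only, known or untested is meant among the compounds shown, and "the series" means these compounds.

In an ADME assay on L929 cells (Mus musculus) for cytotoxicity, read by resazurin assay, with a stated time of 48 h (on this read-out lower numbers stand for higher toxicity in this test and higher numbers for lower toxicity in this test), compound 1 (`C=CCn1c2ccc([N+](=O)[O-])cc2c(=O)n1Cc1ccccc1`) gives 192000 nM, compound 2 (`O=c1c2cc([N+](=O)[O-])ccc2n(CCCBr)n1Cc1ccccc1`) gives 25200 nM, and compound 3 (`CCOC(=O)CCCn1c2ccc([N+](=O)[O-])cc2c(=O)n1Cc1ccccc1`) gives 78100 nM, second highest of the three. Compound 4 (`O=c1c2cc([N+](=O)[O-])ccc2n(CCO)n1Cc1ccccc1`) differs from compound 3 by one change: hydroxy in place of (ethoxycarbonyl)methyl on a saturated chain carbon, two bonds along the chain from an aromatic nitrogen. Within the data shown here, no measured step makes this exact exchange. The closest evidence comes from changes on the same chain: a 2.5-fold lower number from compound 1 to compound 3 (0.39 log units; beyond the scatter), a 7.6-fold lower number from compound 1 to compound 2 (0.88 log units; beyond the scatter) and a 3.1-fold higher number from compound 2 to compound 3 (0.49 log units; beyond the scatter), each modest yet beyond the scatter. A similarly modest move toward a higher number is therefore expected in this assay, with the direction uncertain. The expected change is a 1.5-fold higher number from compound 3 to compound 4 (0.19 log units; within the scatter). Compound 4 is estimated at 120000 nM, with an expected range from 40000 nM to 350000 nM.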

Compound 4, concentration lethal to 50% of the cells: > 256000 nM
Compound 4: no number, only a limit; the forecaster's own chance of this, stated with the estimate: 5%; at least 2.1-fold (0.32 log units) between middle value and limit.
By their numbers in this assay, from the lowest: compound 2; then compound 3; then compound 1. At a limit, above all of these: compound 4.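

Compound 4 gives no number in this assay, only a limit: the limit of > 256000 nM in this assay, at which 1 of the 4 values shown sits. With hydroxy on this chain, the number rises clear of both the ester and the bromide, with an at least 3.2-fold higher number from compound 3 to compound 4 (0.51 log units; beyond the scatter) and an at least 10-fold higher number from compound 2 to compound 4 (1.00 log units; beyond the scatter), so this position can carry a group that shows lower toxicity in this test than either of these. Against compound 1 the order stays unsettled, with an at least 1.3-fold higher number from compound 1 to compound 4 (0.12 log units; that floor lies within the scatter).

The compounds shown leave open whether an amine or a carboxylic acid in place of the hydroxy would reach as high a number, and whether hydroxy on a longer chain would do so.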